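From Heptyl to Isopropoxy on a Carbonyl Carbon

The source may hold more compounds than are shown below. What is called first, only, known or untested is meant among the compounds shown, and "the series" means these compounds.

Of the compounds shown here, three with a shared core have been measured in a functional assay on WI-38 VA13 cells (Homo sapiens) for cytotoxicity; on this read-out higher numbers stand for an effect only at larger amounts of compound and lower numbers for an effect already at smaller amounts. Compound 1 (`O=C(Nc1ccc2nc(NC(=O)C3CCCCC3)sc2c1)c1ccccc1Oc1ccccc1`) gives 0.1 ug/mL, compound 2 (`Cc1coc(C)c1C(=O)Nc1ccc2nc(NC(=O)C3CCCCC3)sc2c1`) gives 2.7 ug/mL, and compound 3 (`CCCCCCCC(=O)Nc1nc2ccc(NC(=O)c3c(Cl)cccc3Cl)cc2s1`) gives 0.18 ug/mL. Compound 3 stands within the usual scatter of compound 1, so those two numbers cannot be told apart. Compound 2 lies beyond the scatter from compound 3, on the higher side, which here means an effect only at larger amounts.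

The next compound is compound 4 (`CC(C)OC(=O)Nc1nc2ccc(NC(=O)c3c(Cl)cccc3Cl)cc2s1`), which has not yet been measured. It carries isopropoxy in place of heptyl on a carbonyl carbon. Among the compounds with values here, no two measured compounds differ in one place only, so the data hold no direct precedent for this change, and the spread of the three values is the only guide. Within the data shown here, the one value far from compound 3 at 0.18 ug/mL is that of compound 2 at 2.7 ug/mL, so a modest move toward higher numbers is expected, though a result within the scatter would be no surprise. The estimated step is a 2.8-fold higher number from compound 3 to compound 4 (0.44 log units; beyond the scatter). The expected value for compound 4 is 0.5 ug/mL, with an estimated range of 0.12 ug/mL to 2.5 ug/mL.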

Compound 4, half-maximal effective concentration: 0.0026 ug/mL
Compound 4: the middle estimate sits 190-fold (2.28 log units) above what was measured; measured number outside the range, below it.
By their numbers in this assay, from the lowest: compound 4; then compounds 1 and 3 (each within the scatter of the next); then compound 2.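

Within the data shown here, compounds 3 and 4 are the first pair here that differ in one place only, and in this assay that single change gives a 69-fold lower number from compound 3 to compound 4 (1.84 log units; beyond the scatter), a large step. This shows that the group on this carbonyl carbon, whose other neighbour is an amide-type nitrogen, strongly affects the cytotoxicity read-out even with the rest of the molecule held the same, and the move is toward an effect at much smaller amounts of compound. Nothing available here explains why the number fell so far.

The change from heptyl to isopropoxy alters the chain and brings in an oxygen at the same time, so the compounds shown cannot separate these two parts; isopropyl on the same carbonyl carbon would keep the short branched chain without the oxygen, while heptyloxy would keep the long chain with the oxygen. As far as these compounds go, it also remains open whether isopropoxy would produce a similar step in place of the group at this position in compound 1 or compound 2, both of which carry a different group on the other side of the shared core.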